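The source may hold more compounds than are shown below. What is called first, only, known or untested is meant among the compounds shown, and "the series" means these compounds.

Measured so far in a functional assay on the whole organism for inhibition, with Rattus norvegicus as the target; a higher number here means that more compound is needed for the effect, a lower number that less compound is needed:
compound 1, `CC1CC/C(=N\Nc2ccccc2)c2nccc(=O)n21`: > 100 umol/kg
compound 2, `CC1CC/C(=N\Nc2cccc(C(=O)O)c2)c2nccc(=O)n21`: > 100 umol/kg
compound 3, `C[C@H]1CCC(=NNc2ccccc2)c2ncc(C(=O)O)c(=O)n21`: 1 umol/kg; > 100 umol/kg (2 entries)

Compound 2 stands only at a limit in this assay, the value > 100 umol/kg being a limit of the assay and not a number. Compound 1 likewise gives only a limit, > 100 umol/kg. Compound 3 gives mixed entries, (the several entries of compound 3 in this assay, 1 umol/kg; > 100 umol/kg (2 entries)), two of them at the same limit, (the limit of > 100 umol/kg in this assay, at which 2 of the 3 values shown sit). Among the compounds with values here, the one measured step, a step that the two limits leave unreadable from compound 1 to compound 2, is therefore unreadable. Compound 4, `CC1CC/C(=N\Nc2cccc(C(=O)O)c2)c2ncc(C(=O)O)c(=O)n21`, differs from compound 2 as follows: carboxy in place of hydrogen on an aromatic carbon. Within the data shown here, no measured step bears directly on this change; compound 1 and compound 3 carry the corresponding two groups, one a limit and one mixed. Compound 4 is therefore expected near the limit again, with a step of an at least 1.6-fold lower number from compound 2 to compound 4 (0.22 log units; that floor lies within the scatter) of uncertain size, and an estimated value of 60 umol/kg (range 5 umol/kg to 300 umol/kg).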

Compound 4, dose for 50% inhibition: > 100 umol/kg
Compound 4 was reported as a limit; the forecaster's own chance of this, stated with the estimate: 60%; at least 1.6-fold (0.22 log units) between middle value and limit.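

Compound 2 and compound 4 both stand only at limits in this assay, so no step can be read between them. From the compounds shown here alone, whether carboxy in place of hydrogen on an aromatic carbon shifts the dose needed, and how far, stays open.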